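The compounds below may be only part of what the source reports. "The series", "measured", "known", "first", "only" and "open" are said of these compounds alone.

Compound 1 `CNc1ncnc2c1c(-c1cc3ccccc3o1)cn2[C@@H]1O[C@H](CO)[C@@H](O)[C@H]1O` gives in a functional assay on CCRF-CEM cells (Homo sapiens), read by MTT assay, with a stated time of 72 h (on this read-out lower numbers stand for stronger inhibition and higher numbers for weaker inhibition), only a limit of the assay, > 20000 nM.
Compound 2 `CNc1ncnc2c1c(-c1ccco1)cn2[C@@H]1O[C@H](CO)[C@@H](O)[C@H]1O` gives in this assay 180 nM.
Compound 3 `Nc1nc(N)c2c(-c3cc4ccccc4o3)cn([C@@H]3O[C@H](CO)[C@@H](O)[C@H]3O)c2n1` gives in this assay only a limit of the assay, > 20000 nM.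

The change from compound 1 to compound 2 is furan-2-yl in place of 1-benzofuran-2-yl on an aromatic carbon. It brings an at least 110-fold lower number from compound 1 to compound 2 (2.04 log units; beyond the scatter). Compound 3 differs from compound 1 in the core, and that difference is not broken down here. Compound 4 `Nc1nc(N)c2c(-c3ccco3)cn([C@@H]3O[C@H](CO)[C@@H](O)[C@H]3O)c2n1` carries the same change on the core of compound 3, namely (furan-2-yl in place of 1-benzofuran-2-yl on an aromatic carbon). Because compound 1 and compound 3 both sit at the limit of > 20000 nM in this assay, at which 2 of the 3 values shown sit, the true size of the earlier step is itself open. Compound 4 is expected to reach about 1500 nM in this assay, between 150 nM and 20000 nM. The expected step is an at least 13-fold lower number from compound 3 to compound 4 (1.12 log units; beyond the scatter), which rests on the measured step of an at least 110-fold lower number from compound 1 to compound 2 (2.04 log units; beyond the scatter).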

Compound 4, half-maximal inhibitory concentration: > 20000 nM
Compound 4 ended at the assay's limit; the forecaster's own chance of this, stated with the estimate: 30%; middle value at least 13-fold (1.12 log units) away from the limit.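

No step can be read between compound 3 and compound 4, because both end at the same limit of the assay: the limit of > 20000 nM in this assay, at which 3 of the 4 values shown sit. The compounds shown leave open whether furan-2-yl in place of 1-benzofuran-2-yl changes anything on the core of compound 3.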